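Shortening the side chain of compound 3

The source may report more compounds than this note shows. Statements on the series, on what has been measured and on what is new or still open speak of the compounds shown alone.

Measured in an ADME assay on L929 cells (Mus musculus, culture collection number NCTC 929) for cytotoxicity, read by MTT assay, with a stated time of 72 h; a higher number here means a weaker inhibitor, a lower number a stronger inhibitor:
Compound 1 `CCCCCCCCCC(=O)c1c(O)cc(C)oc1=O`: 134000 nM
Compound 2 `CCCCCCCCCCCCCC(=O)c1c(O)cc(C)oc1=O`: > 200000 nM (a limit, not a number)
Compound 3 `Cc1cc(O)c(C(=O)CCC2CCCCC2)c(=O)o1`: 117000 nM

Compound 3 gives 117000 nM and compound 1 gives 134000 nM, two values within the scatter of each other. For compound 2, the assay reports only a limit, > 200000 nM.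

Compound 4 `CCCCCC(=O)c1c(O)cc(C)oc1=O`, not yet measured, carries propyl in place of cyclohexyl on a saturated chain carbon, two bonds along the chain from a carbonyl carbon. Among the measured compounds shown here, the one measured step that bears on this is also a change in the chain: an at least 1.4-fold higher number from compound 1 to compound 2 (0.17 log units; that floor lies within the scatter). Its size is bounded by the limit of > 200000 nM in this assay, at which 1 of the 3 values shown sits, so it remains uncertain. In this assay, no change beyond the scatter is therefore expected, though a higher number remains possible. The estimated step is a 1.2-fold higher number from compound 3 to compound 4 (0.08 log units; within the scatter). For compound 4, the expected value is 140000 nM, within an estimated range from 70000 nM to 280000 nM.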

Compound 4, half-maximal inhibitory concentration: > 200000 nM
Compound 4: a limit, no number; the forecaster's own chance of this, stated with the estimate: 30%; at least 1.4-fold (0.15 log units) between middle value and limit.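

In this assay, propyl in place of cyclohexyl gives an at least 1.7-fold higher number from compound 3 to compound 4 (0.23 log units; that floor lies within the scatter) and hydrogen in place of butyl gives an at least 1.4-fold higher number from compound 1 to compound 4 (0.17 log units; that floor lies within the scatter). Shortening the chain of compound 1 to that of compound 4 thus ends at a limit, as lengthening it to that of compound 2 does, though both floors stay within the scatter. The step between compound 2 and compound 4 cannot be read, because each carries only a limit: the limit of > 200000 nM in this assay, at which 2 of the 4 values shown sit.

On these data alone, how far compound 4 lies past its limit stays open. So does how a chain ending in an amine or a carboxylic acid would read in this assay.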